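Working notes: from compound 1 to compound 3

This account rests on a few compounds, and the source may have more. Where it says the series, first, only, none or still open, it means among the compounds named here.

Measured in an ADME assay on the whole organism (strain Sprague-Dawley) for pharmacokinetics, with Rattus norvegicus as the target, read by LC-MS, using cassette dosing, at a dose of 0.5 mg/kg by the intravenous route; a lower number here means slower removal, a higher number faster removal of the compound:
- compound 1 `C[C@@]1(c2cc(NC(=O)c3cnc(OCF)cn3)ccc2F)C=C(CF)OC(N)=N1`: 34.4 mL/min/kg
- compound 2 `C[C@@]1(c2cc(NC(=O)c3ncc(OCF)nc3N)ccc2F)C=C(CF)OC(N)=N1`: 45.3 mL/min/kg

Going by the values given here, compound 1 gives 34.4 mL/min/kg, which lies within the scatter of the only other measured compound. Compound 3 `C[C@@]1(c2cc(NC(=O)c3ccc(C#N)cn3)ccc2F)C=C(CF)OC(N)=N1` carries 5-cyanopyridin-2-yl in place of 5-(fluoromethoxy)pyrazin-2-yl on a carbonyl carbon. Among the compounds with values here, the sole measured step, amino in place of hydrogen on an aromatic carbon, is a 1.3-fold higher number from compound 1 to compound 2 (0.12 log units; within the scatter). It bears only loosely on this replacement and gives no direction, so no shift beyond the scatter is expected in this assay. The expected step is a 1.1-fold lower number from compound 1 to compound 3 (0.06 log units; within the scatter). Compound 3 is estimated at 30 mL/min/kg, with a range of 15 mL/min/kg to 58 mL/min/kg.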

Compound 3, clearance: 16.8 mL/min/kg
The estimate for compound 3 lay 1.8-fold (0.25 log units) above the measured number; the measured number falls inside the stated range.
By their numbers in this assay, from the lowest: compound 3; then compounds 1 and 2 (each within the scatter of the next).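

In this assay, replacing the whole group on the carbonyl carbon moves the number beyond the scatter, which the amino step did not do: 5-cyanopyridin-2-yl in place of 5-(fluoromethoxy)pyrazin-2-yl gives (a 2.0-fold lower number from compound 1 to compound 3 (0.31 log units; beyond the scatter)), and in place of 3-amino-5-(fluoromethoxy)pyrazin-2-yl gives (a 2.7-fold lower number from compound 2 to compound 3 (0.43 log units; beyond the scatter)). No measured evidence on hand accounts for either step.

The nitrile, the ring and the loss of fluoromethoxy change together, so the steps cannot be assigned to any one of them. As far as these compounds go, how a primary amide or a methoxy group in place of the nitrile would read remains open.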